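Moving a methyl around the phenoxy ring

The source may hold more compounds than are shown below. What is called first, only, known or untested is meant among the compounds shown, and "the series" means these compounds.

Two compounds share one core and differ only in the aryl group carried on an oxygen on an aromatic ring. Compound 1 `Cc1nn(C)c(Oc2ccc(I)cc2)c1/C=N\CCCCCCOc1cc2oc(=O)cc(C)c2cc1Cl` gives 16800 nM in a functional assay on U-87MG ATCC cells for antiproliferative activity against U-87 MG (Homo sapiens), read by MTT assay, with a stated time of 72 h; on this read-out lower numbers stand for stronger inhibition and higher numbers for weaker inhibition. Within the data shown here, compound 2 `Cc1ccccc1Oc1c(/C=N\CCCCCCOc2cc3oc(=O)cc(C)c3cc2Cl)c(C)nn1C` gives 9610 nM in this assay, the lowest of the two numbers so far, though the step of a 1.7-fold lower number from compound 1 to compound 2 (0.24 log units; within the scatter) places the two within the scatter of each other, so neither can be called the stronger.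

Compound 3 `Cc1ccc(Oc2c(/C=N\CCCCCCOc3cc4oc(=O)cc(C)c4cc3Cl)c(C)nn2C)cc1` has the same atoms as compound 2 joined differently: 4-methylphenyl in place of 2-methylphenyl on an oxygen on an aromatic ring. Among the measured compounds shown here, the only measured step that bears on this position is a 1.7-fold lower number from compound 1 to compound 2 (0.24 log units; within the scatter), and it shows that swapping one aryl group for another there, even one with a different halogen and substitution, moved the number by less than the scatter. On that basis the expected step in this assay from compound 2 to compound 3 is small, a 1.0-fold higher number from compound 2 to compound 3 (0.02 log units; within the scatter), with no clear direction. Compound 3 is therefore estimated at 10000 nM, with a likely range from 4500 nM to 22000 nM.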

Compound 3, half-maximal inhibitory concentration: 23600 nM
The estimate for compound 3 lay 2.4-fold (0.37 log units) below the measured number; the whole stated range lies below it.
By their numbers in this assay, from the lowest: compounds 2, 1 and 3 (each within the scatter of the next, the first and the last beyond it).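

The swap of 2-methylphenyl for 4-methylphenyl gives a 2.5-fold higher number from compound 2 to compound 3 (0.39 log units; beyond the scatter) in this assay. Among these compounds, this modest change is the first step to lie beyond the scatter, and it shows that the arrangement of the methyl on the ring can shift the number even when the two groups have the same atoms and the same counted features, something the earlier pair could not show. The replacement of iodo by methyl on an aromatic carbon gives a 1.4-fold higher number from compound 1 to compound 3 (0.15 log units; within the scatter), which lies within the scatter, so this assay does not separate those two compounds.

The compounds shown leave open how a 3-methylphenyl group, a methoxy group or an amine on the phenyl ring would compare, and whether the effect of moving the methyl would persist with a longer chain in the same core. No measurement offered here gives a reason for the difference between the 2-methylphenyl and 4-methylphenyl compounds.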